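A few compounds are considered here, and "the series" means these few. Any claim that something is new, unique, unknown or untested is made for them only; others in the source may bear on it.

Measured compounds:
compound 1 `O=C(Nc1cccc(-n2cc(-c3ccncc3)c(-c3ccc(Cl)c(O)c3)n2)c1)Nc1cccc(C(F)(F)F)c1` gives 26800 nM
compound 2 `COc1cc(-c2nn(-c3cccc(NC(=O)c4cccc(C(F)(F)F)c4)c3)cc2-c2ccncc2)ccc1Cl` gives 9960 nM
compound 3 `O=C(Nc1cccc(-n2cc(-c3ccncc3)c(-c3ccc(Cl)c(O)c3)n2)c1)Nc1cc(C(F)(F)F)cc(C(F)(F)F)c1` gives 1660 nM

In a functional assay on MDA-MB-231 cells (Homo sapiens) for inhibition, read by sulforhodamine B assay, with a stated time of 48 h (on this read-out higher numbers stand for weaker inhibition of growth and lower numbers for stronger inhibition of growth), compound 2 stands second highest of the three numbers: compound 1 gives a higher number, 26800 nM, and compound 3 a lower one, 1660 nM, with both gaps beyond the scatter. Among the measured compounds shown here, compound 2 is the only one of the three whose carbonyl carries an aryl directly rather than a second amine, and it also carries methoxy where compounds 1 and 3 carry hydroxyl, so no single step links it to either of them.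

Compound 4 `COc1cc(-c2nn(-c3cccc(NC(=O)Nc4ccc(Cl)c(C(F)(F)F)c4)c3)cc2-c2ccncc2)ccc1Cl` is not yet measured. It differs from compound 2 by (4-chloro-3-(trifluoromethyl)phenyl)amino in place of 3-(trifluoromethyl)phenyl on a carbonyl carbon, so compound 4 becomes a urea like compounds 1 and 3, with a chlorine added on the distal ring. For the measured compounds named here, the one measured step that bears on it is the addition of a substituent on that distal ring, a 16-fold lower number from compound 1 to compound 3 (1.21 log units; beyond the scatter), a large drop in the number. Going by the values given here, no measured step covers the change from the directly attached aryl to the aryl-amine, so that part rests on no data. A lower number is expected for compound 4, with a 4.0-fold lower number from compound 2 to compound 4 (0.60 log units; beyond the scatter), and compound 4 is estimated at 2500 nM, within 800 nM to 8000 nM.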

Compound 4, concentration for total growth inhibition: 2600 nM
Estimate against measurement, compound 4: 1.0-fold (0.02 log units) below; low and high end bracket the measured number.
By their numbers in this assay, from the lowest: compounds 3 and 4 (each within the scatter of the next); then compound 2; then compound 1.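

In this assay, among the compounds shown here, the change on this carbonyl carbon gives a 3.8-fold lower number from compound 2 to compound 4 (0.58 log units; beyond the scatter), the first measured step that joins compound 2, with its directly attached aryl, to a urea. The earlier step concerned only the substituents on the aryl ring of two ureas that carry hydroxyl, whereas this one shows that replacing 3-(trifluoromethyl)phenyl with (4-chloro-3-(trifluoromethyl)phenyl)amino also lowers the number beyond the scatter when methoxy is present and the link to the ring changes as well. No measurement available here bears on why the number falls. The step also combines two alterations, the added amino nitrogen with its hydrogen-bond donor and the added chlorine, so the compounds shown cannot assign its size to either one. They leave open how much of the step would remain with a methylene in place of the amino nitrogen, and whether a nitrile or a methyl group in place of the chlorine would give a similar number.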